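This account rests on a few compounds, and the source may have more. Where it says the series, first, only, none or still open, it means among the compounds named here.

Measured so far:
- compound 1 `O=C(Nc1ccc(Oc2ccnc3[nH]ccc23)cc1)c1cc2cccnc2n(-c2ccc(F)c(Cl)c2)c1=O`: 680 nM
- compound 2 `O=C(Nc1ccc(Oc2ccnc3[nH]ccc23)c(F)c1)c1cc2cccnc2n(-c2ccccc2)c1=O`: 190 nM
- compound 3 `O=C(Nc1ccc(Oc2ccnc3[nH]ccc23)c(F)c1)c1cc2cccnc2n(-c2ccc(Br)cc2)c1=O`: 210 nM

All three values come from a functional assay on A549 cells (Homo sapiens) for antiproliferative activity, read by MTT assay, with a stated time of 72 h; a higher number here means a weaker inhibitor, a lower number a stronger inhibitor. Compound 3 stands second highest of the three numbers. Its nearest neighbour is compound 2, and the step of a 1.1-fold higher number from compound 2 to compound 3 (0.04 log units; within the scatter) is within the scatter, so the two cannot be ordered. Furthest off is compound 1, whose number in this assay is higher than that of compound 3 beyond the scatter; compound 1 differs from compound 3 in two places, however, so no single step can be read from that pair.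

Compound 4 `O=C(Nc1ccc(Oc2ccnc3[nH]ccc23)c(F)c1)c1cc2cccnc2n(-c2ccc(F)c(Cl)c2)c1=O` is not yet measured. It differs from compound 3 by 3-chloro-4-fluorophenyl in place of 4-bromophenyl on an aromatic nitrogen, the aryl group on the aromatic nitrogen being the same one carried by compound 1. Within the data shown here, the only measured step at this position, a 1.1-fold higher number from compound 2 to compound 3 (0.04 log units; within the scatter), is within the scatter, which suggests that exchanging substituents on this aryl ring changes little in this assay. The higher number of compound 1 in this assay leaves some room for the 3-chloro-4-fluorophenyl to push the value upward, but that pair also differs by the fluorine on the anilide ring, so its weight is limited.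

Compound 4 is therefore expected to show a step of a 1.4-fold higher number from compound 3 to compound 4 (0.15 log units; within the scatter) of modest size, if any, and its value in this assay is estimated at 300 nM, within a range of 120 nM to 800 nM.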

Compound 4, half-maximal inhibitory concentration: 630 nM
The estimate for compound 4 lay 2.1-fold (0.32 log units) below the measured number; low and high end bracket the measured number.
By their numbers in this assay, from the lowest: compounds 2 and 3 (each within the scatter of the next); then compounds 4 and 1 (each within the scatter of the next).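

In this assay, the aryl group on the aromatic nitrogen is not as indifferent to exchange as the phenyl and 4-bromophenyl pair suggested (compounds 2 and 3 could not be separated). Replacing 4-bromophenyl with 3-chloro-4-fluorophenyl gives a step beyond the scatter (a 3.0-fold higher number from compound 3 to compound 4 (0.48 log units; beyond the scatter)), and replacing phenyl with the same group gives a step of similar size (a 3.3-fold higher number from compound 2 to compound 4 (0.52 log units; beyond the scatter)). With 3-chloro-4-fluorophenyl in place, the one remaining difference between the two compounds carrying this group does not separate them (a 1.1-fold lower number from compound 1 to compound 4 (0.03 log units; within the scatter)), and no measurement in hand accounts for the effect of the aryl exchange.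

It remains open whether the step follows the chloro, the fluoro or the two together, since 3-chlorophenyl and 4-fluorophenyl are not among the compounds shown. Also open, going by these compounds, is how this position responds to a group outside the halogenated aryl set, such as 4-methoxyphenyl, a 4-aminophenyl or a simple methyl on the aromatic nitrogen.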